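Bromomethyl on the core: step from compound 1 to compound 4

A few compounds are considered here, and "the series" means these few. Any claim that something is new, unique, unknown or untested is made for them only; others in the source may bear on it.

Compound 1 `O=C1C=CS(=O)(=O)c2ccccc21` is the bare core of the series. In a functional assay on the whole organism for inhibition, with Mus musculus as the target, at a dose of 10 mg/kg (on this read-out lower numbers stand for less inhibition and higher numbers for more inhibition at the one dose given (going by the name of the read-out)), compound 1 gives 5.5%, the lowest of the three numbers in hand. Compound 2 `O=C1C(COCCBr)=CS(=O)(=O)c2ccccc21` gives 100% and compound 3 `CC(=O)OCC1=CS(=O)(=O)c2ccccc2C1=O` gives 99.5%, so both substituted members sit far above compound 1.

Compound 4 `O=C1C(CBr)=CS(=O)(=O)c2ccccc21` differs from compound 1 in one place: bromomethyl in place of hydrogen on a double-bonded ring carbon. The two measured steps that bear on this change are a number 94.5 percentage points higher from compound 1 to compound 2 (beyond the scatter) and a number 94 percentage points higher from compound 1 to compound 3 (beyond the scatter); both put a group on the same double-bonded ring carbon and both move the read-out by a large amount. The step of a number 0.5 percentage points lower from compound 2 to compound 3 (within the scatter) shows that swapping the group on the oxygen of the side chain leaves the read-out unchanged, so the size of the group at that carbon has not mattered between compounds 2 and 3. Among the compounds with values here, compound 4 carries a shorter group there than either, and no other member tests a group of that length.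

A large upward step is therefore expected; the step of a number 89.5 percentage points higher from compound 1 to compound 4 (beyond the scatter) is the estimate. Compound 4 is expected to give 95%, with a range of 70% to 100%.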

Compound 4, a percentage reported as inhibition, in the whole organism at one dose (the size of the read-out at that dose, not a potency): 92.8%
For compound 4 the middle estimate is 2.2 percentage points above the measured one; the measured number falls inside the stated range.
By their numbers in this assay, from the lowest: compound 1; then compounds 4, 3 and 2 (each within the scatter of the next).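

In this assay, bromomethyl on the double-bonded ring carbon gives a step of a number 87.3 percentage points higher from compound 1 to compound 4 (beyond the scatter) on its own, so the large rise does not need a group as long as those of compounds 2 and 3. Beyond that carbon, the group on the saturated chain carbon does not separate the compounds at this dose: bromo in place of acetoxy gives a step of a number 6.7 percentage points lower from compound 3 to compound 4 (within the scatter) and bromo in place of 2-bromoethoxy gives a step of a number 7.2 percentage points lower from compound 2 to compound 4 (within the scatter), both within the scatter. Nothing in hand explains the rise seen with these groups or why the three substituted compounds cannot be told apart.

Going by these compounds, it remains open whether a plain methyl, a hydroxymethyl or an aminomethyl group on the same carbon would give a number near those of compounds 2, 3 and 4 or one near that of compound 1, which would show whether a leaving bromo or acetoxy group matters at all. Also open, on these data alone, is whether compounds 2, 3 and 4 would separate at another dose, since a reading at one dose is not a potency.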